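The source may report more compounds than this note shows. Statements on the series, on what has been measured and on what is new or still open speak of the compounds shown alone.

Compound 2, whose structure is `Nc1nn(C(=O)Nc2ccc(Cc3ccccc3)cc2)c2ccc(Cl)cc12`, is tested in a functional assay on SK-MEL-5 cells (Homo sapiens) for antiproliferative activity, read by sulforhodamine B assay, with a stated time of 48 h (a higher number here means that more compound is tolerated, a lower number that less compound is tolerated), where compound 2 gives 80200 nM. Among the two measured compounds it holds the higher number; its only neighbour is compound 1, the parent `Nc1nn(C(=O)Nc2ccc(Cc3ccccc3)cc2)c2ccccc12`, which in this assay gives 34300 nM. Among the compounds with values here, the one measured step, a 2.3-fold higher number from compound 1 to compound 2 (0.37 log units; beyond the scatter), arises from a chloro in place of hydrogen on an aromatic carbon of the fused ring of the shared core.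

Compound 3, `Nc1ccc2c(c1)c(N)nn2C(=O)Nc1ccc(Cc2ccccc2)cc1`, is not yet measured in this assay. It differs from compound 2 by amino in place of chloro on an aromatic carbon, the place being an aromatic carbon of a six-membered aromatic ring of carbon only, part of a fused system of two rings, meta to a fused ring and para to a fused ring. The step from compound 1 to compound 2 bears on this change only in part: it shows that losing the chloro would be expected to undo a modest rise, while nothing measured speaks to what an amino at that place adds. The expectation for compound 3 is therefore a modest fall back toward the level of compound 1, so that the estimated step is a 2.0-fold lower number from compound 2 to compound 3 (0.30 log units; within the scatter). Compound 3 is accordingly estimated to give 40000 nM, within a range of 15000 nM to 110000 nM.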

Compound 3, concentration lethal to 50% of the cells: 46400 nM
Estimate against measurement, compound 3: 1.2-fold (0.06 log units) below; measured number inside the range.
By their numbers in this assay, from the lowest: compounds 1, 3 and 2 (each within the scatter of the next, the first and the last beyond it).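

In this assay, an amino group on this aromatic carbon of the six-membered ring of carbon only brings a 1.4-fold higher number from compound 1 to compound 3 (0.13 log units; within the scatter), whereas chloro in the same place had brought a step beyond the scatter. Exchanging chloro for amino gives a 1.7-fold lower number from compound 2 to compound 3 (0.24 log units; within the scatter), so compound 3 cannot be told apart from either of its two neighbours, although those neighbours do stand apart from each other. At this place, then, the two substituents shown do not separate cleanly: only chloro differs from hydrogen beyond the scatter, and amino, which enters with a hydrogen-bond donor and acceptor that chloro lacks, lies within the scatter of both. No measurement at hand accounts for either step.

From the compounds shown here alone, what remains open is whether another group at this place, such as fluoro, methoxy or a carboxylic acid, would shift the number beyond the scatter from compound 1, and in which direction. The compounds shown also leave open whether chloro or amino on any other aromatic carbon of the shared core would give steps of similar size.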